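Bromo in Place of Propylamino on a Weakly Inhibiting Core

A few compounds are considered here, and "the series" means these few. Any claim that something is new, unique, unknown or untested is made for them only; others in the source may bear on it.

Compound 2, `CCCNc1nc2cc(Cl)c(Cl)cc2n1[C@@H]1O[C@@H](C)[C@@H](O)[C@H]1O`: 65000 nM in a functional assay on KB cells (Homo sapiens) for inhibition; on this read-out higher numbers stand for weaker inhibition and lower numbers for stronger inhibition
Compound 1, `C[C@H]1O[C@@H](n2c(Br)nc3cc(Cl)c(Cl)cc32)[C@H](O)[C@@H]1O`: the limit > 100000 nM
Compound 3, `CCCNc1nc2cc(Cl)c(Cl)cc2n1[C@@H]1O[C@@H](CO)[C@@H](O)[C@H]1O`: the limit > 100000 nM

Compound 2 is the only one of the three that gives a number rather than a limit in this assay. Compound 4, `C[C@@H]1O[C@@H](n2c(Br)nc3cc(Cl)c(Cl)cc32)[C@H](O)[C@@H]1O`, is not yet measured; it differs from compound 2 by bromo in place of propylamino on an aromatic carbon. Going by the values given here, the one measured step, an at least 1.5-fold higher number from compound 2 to compound 3 (0.18 log units; that floor lies within the scatter), concerns another part of the molecule and lies within the scatter, so it offers no guide to this change. Compound 1 also carries bromo and sits at the limit of > 100000 nM in this assay, at which 2 of the 3 values shown sit. Compound 4 is expected to inhibit no better than compound 2, with an estimated step of a 2.3-fold higher number from compound 2 to compound 4 (0.36 log units; beyond the scatter), most likely ending at the limit. The estimate for compound 4 is 150000 nM, ranging from 60000 nM to 400000 nM.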

Compound 4, half-maximal inhibitory concentration: 60000 nM
For compound 4 the middle estimate is 2.5-fold (0.40 log units) above the measured one; the range from low to high includes it.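

Bromo in place of propylamino on the aromatic carbon between two ring nitrogen atoms gives a 1.1-fold lower number from compound 2 to compound 4 (0.03 log units; within the scatter), so this swap leaves inhibition unchanged within the scatter, even though a much smaller group with no hydrogen-bond donor enters. Compound 1 carries the same bromo, but its > 100000 nM is a limit, not a number. The configuration at one saturated ring carbon gives an at least 1.6-fold lower number from compound 1 to compound 4 (0.22 log units; that floor lies within the scatter), so no effect of that stereocentre can be claimed.

From the compounds shown here alone, the true size of that stereocentre's effect stays open. So does whether chloro or a longer chain such as pentylamino at this position would give a clearly lower number.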